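The source may report more compounds than this note shows. Statements on the series, on what has been measured and on what is new or still open speak of the compounds shown alone.

Measured compounds:
Compound 1 `CNc1ccccc1N1CCN(CCCCn2ncc(=O)n(C)c2=O)CC1`: 450 nM
Compound 2 `Cn1c(=O)cnn(CCCCN2CCN(c3ccc(F)cn3)CC2)c1=O`: a limit, > 10000 nM

In an assay for displacement of a labelled ligand from Adrenergic receptor alpha-1 (Homo sapiens) (on this read-out lower numbers stand for stronger inhibition and higher numbers for weaker inhibition), compound 1 gives 450 nM. Compound 2 is reported only as a limit of the assay, > 10000 nM, and so sits at the limit of > 10000 nM in this assay, at which 1 of the 2 values shown sits. Going by the values given here, the single measured step, an at least 22-fold higher number from compound 1 to compound 2 (1.34 log units; beyond the scatter), is the whole of what is known about changing the group on the ring nitrogen, and it is large.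

Compound 3 `Cn1c(=O)cnn(CCCCN2CCN(c3ncccc3F)CC2)c1=O` differs from compound 2 by 3-fluoropyridin-2-yl in place of 5-fluoropyridin-2-yl on an amine nitrogen in a ring. Among the compounds with values here, no measured step shifts a fluorine around the pyridine; the step from compound 1 to compound 2 exchanged the entire group. The expectation for compound 3 therefore rests on compound 2 standing at a limit, and compound 3 is expected to show no step beyond the scatter, a step that the limit leaves unreadable from compound 2 to compound 3, with a good chance that it too is reported only as a limit. Compound 3 is estimated at 15000 nM, within 3000 nM to 60000 nM.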

Compound 3, inhibition constant: > 10000 nM
Compound 3: a limit, no number; the forecaster's own chance of this, stated with the estimate: 70%; the middle value is on the limit's open side.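

In this assay compound 3 is also reported only as a limit, > 10000 nM. On the same amine nitrogen in a ring, 3-fluoropyridin-2-yl in place of 2-(methylamino)phenyl gives an at least 22-fold higher number from compound 1 to compound 3 (1.34 log units; beyond the scatter), so the large step seen with 5-fluoropyridin-2-yl is not tied to that one fluorine placement. The step between the two fluoropyridinyl compounds cannot be read, because both stand at the limit: the limit of > 10000 nM in this assay, at which 2 of the 3 values shown sit.

As far as these compounds go, it remains open whether the methylamino group or the phenyl ring accounts for the lower number of compound 1, which a plain phenyl group or an unsubstituted pyridin-2-yl group would help to separate. From the compounds shown here alone, it is also open whether a pyridine carrying a methylamino group on this nitrogen would come back inside the measurable range.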